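This account rests on a few compounds, and the source may have more. Where it says the series, first, only, none or still open, it means among the compounds named here.

Compound 1 `CCN(Cc1ccc(F)cc1)c1ccc(C(=O)N2CCc3ccc(OS(N)(=O)=O)cc3C2)cc1` carries a sulfamate on its core and an amide-linked aryl ring bearing an ethyl(4-fluorobenzyl)amino group. In an assay on HEK293 cells for inhibition of Steryl-sulfatase (Homo sapiens), tested at 1 uM (a higher number here means a stronger effect of the compound at the concentration tested, a lower number a weaker effect), compound 1 gives 91.2%, the highest of the two numbers measured here. The other measured compound, compound 2 `NS(=O)(=O)Oc1ccc2c(c1)CN(C(=O)c1ccc(N3CCC(N4CCCCC4)CC3)cc1)CC2`, shares the sulfamate core and the amide link but carries a different amine on the aryl ring; in this assay compound 2 gives 53.7%, a number well below that of compound 1 and outside the usual scatter of such measurements. Within the data shown here, since compound 2 differs from compound 1 in more than one place, no single step between them can be named.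

Compound 3 `CCN(Cc1ccncc1)c1ccc(C(=O)N2CCc3ccc(OS(N)(=O)=O)cc3C2)cc1` has not yet been measured. It differs from compound 1 in one place only: pyridin-4-yl in place of 4-fluorophenyl on a saturated chain carbon bound to a nitrogen on an aromatic ring. Among the measured compounds shown here, no measured pair shows this particular change, so its effect is an expectation rather than a known step. A modest downward step is expected, possibly no larger than the scatter, giving a number 11.2 percentage points lower from compound 1 to compound 3 (beyond the scatter). Compound 3 is therefore estimated to reach 80% in this assay, within a range from 55% to 95%.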

Compound 3, a percentage reported as inhibition, at one concentration (the size of the read-out at that concentration, not a potency): 86.6%
Beside the measured number, compound 3's estimate is 6.6 percentage points below it; the range from low to high includes it.
By their numbers in this assay, from the lowest: compound 2; then compounds 3 and 1 (each within the scatter of the next).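

Until now nothing showed what the ring on the 4-fluorobenzyl arm contributes, since compound 1 and compound 2 differ in more than one place. In this assay, putting pyridin-4-yl in place of 4-fluorophenyl on a saturated chain carbon bound to a nitrogen on an aromatic ring gives a number 4.6 percentage points lower from compound 1 to compound 3 (within the scatter), so the two compounds cannot be told apart here, even though the carbon-only ring carrying fluorine has given way to a ring with a hetero atom and a hydrogen-bond acceptor. Nothing measured here explains why this exchange leaves the read-out within the scatter.

The result covers only these two rings at this place, so a plain phenyl, a cyclohexyl ring or a group carrying a carboxylic acid could still behave quite differently. Both numbers also come from a single tested concentration and sit high on the scale, so a real difference in potency between compound 1 and compound 3 could remain hidden until full concentration series are compared.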